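The compounds below may be only part of what the source reports. "The series", "measured", "known", "first", "only" and "open" are said of these compounds alone.

In a functional assay on U-251 cells (Homo sapiens) for antiproliferative activity, read by MTT assay, with a stated time of 24 h (on this read-out higher numbers stand for weaker inhibition and lower numbers for stronger inhibition), compound 3 (`COc1cc(OC)c(-c2coc3cc(OCc4cccc(Cl)c4)ccc3c2=O)cc1OC`) gives > 10000 nM, which is a limit of the assay and not a number. Compound 1 (`COc1cccc(C(=O)Oc2ccc3c(=O)c(-c4cc(OC)c(OC)cc4OC)coc3c2)c1`) gives > 10000 nM, also a limit. Compound 2 (`COc1cc(OC)c(-c2coc3cc(OCc4ccccc4C)ccc3c2=O)cc1OC`) alone has a number, 2000 nM. The set therefore shows (the limit of > 10000 nM in this assay, at which 2 of the 3 values shown sit).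

Compound 4 (`COc1cc(OC)c(-c2coc3cc(OCc4ccc(C(F)(F)F)cc4)ccc3c2=O)cc1OC`) has 4-(trifluoromethyl)phenyl in place of 3-chlorophenyl on a saturated chain carbon bound to an oxygen on an aromatic ring. Going by the values given here, the closest precedent is an at least 5.0-fold higher number from compound 2 to compound 3 (0.69 log units; beyond the scatter), where the same group changes. The other steps replace (3-methoxyphenyl)carbonyl: an at least 5.0-fold lower number from compound 1 to compound 2 (0.69 log units; beyond the scatter), and a step that the two limits leave unreadable from compound 1 to compound 3. These steps show that the group can matter in this assay, but they give no trend for the new substituent. With compound 3 at > 10000 nM, only a modest move to a lower number can be expected, and compound 4 may well stay at the limit. The expected change is an at least 1.2-fold lower number from compound 3 to compound 4 (0.09 log units; that floor lies within the scatter). For compound 4 the estimated value is 8000 nM, with an expected range of 2500 nM to 20000 nM.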

Compound 4, half-maximal inhibitory concentration: 3750 nM
Estimate against measurement, compound 4: 2.1-fold (0.33 log units) above, and the stated range covers the measured number.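

In this assay, going by these compounds alone, 4-(trifluoromethyl)phenyl in place of 3-chlorophenyl on a saturated chain carbon bound to an oxygen on an aromatic ring gives an at least 2.6-fold lower number from compound 3 to compound 4 (0.42 log units; beyond the scatter), so 2-methylphenyl is no longer the only group here to give a number. Against that group the change gives a 1.9-fold higher number from compound 2 to compound 4 (0.27 log units; within the scatter), so the two cannot be told apart, while 3-chlorophenyl goes against them. The change from (3-methoxyphenyl)carbonyl to 4-(trifluoromethyl)benzyl gives an at least 2.6-fold lower number from compound 1 to compound 4 (0.42 log units; beyond the scatter), and the two steps that start from a limit give only a floor for their size: the limit of > 10000 nM in this assay, at which 2 of the 4 values shown sit.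

From the compounds shown here alone, what 4-chlorobenzyl or 3-(trifluoromethyl)benzyl would give at this place stays open, and with it whether the substituent or where it sits drives the step. Also open, going by these compounds, is how a benzyl carrying an amine or a carboxylic acid would read.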